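The source may report more compounds than this note shows. Statements on the series, on what has been measured and on what is new or still open speak of the compounds shown alone.

Compound 1, `COc1ccccc1NC(=O)CCCCCCNC(=O)C(O)(O)C(F)(F)F`: 10100 nM
Compound 2, `O=C(CCCCCCNC(=O)C(O)(O)C(F)(F)F)Nc1ccc(Cl)cc1`: 4230 nM
Compound 3, `O=C(CCCCCCNC(=O)C(O)(O)C(F)(F)F)Nc1ccc(F)cc1F`: 18500 nM

All three share the same core and differ only in the aromatic group attached to an amide-type nitrogen. In a functional assay on HCT-116 cells (Homo sapiens) for inhibition, read by colorimetric assay, with a stated time of 3 days (a lower number here means a stronger inhibitor, a higher number a weaker inhibitor), compound 2 gives the lowest number of the three: the step of a 2.4-fold lower number from compound 1 to compound 2 (0.38 log units; beyond the scatter) and the step of a 4.4-fold higher number from compound 2 to compound 3 (0.64 log units; beyond the scatter) both place it at the strong end, with compound 3 furthest away. The step of a 1.8-fold higher number from compound 1 to compound 3 (0.26 log units; within the scatter) shows that compound 1 and compound 3 cannot be told apart.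

Compound 4, `O=C(CCCCCCNC(=O)C(O)(O)C(F)(F)F)Nc1ccc(-c2ccccc2)cc1`, is the next change from compound 2: phenyl in place of chloro on an aromatic carbon. Within the data shown here, none of the measured steps swaps a chloro for a phenyl, so the only guide is that changes to this aromatic group have so far moved the number by modest amounts in either direction. A step of similar size, or none beyond the scatter, is the reasonable expectation here, with no firm direction.

Compound 4 is therefore expected to give about 4000 nM, within a range of 1300 nM to 13000 nM. This estimate corresponds to an expected step of a 1.1-fold lower number from compound 2 to compound 4 (0.02 log units; within the scatter).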

Compound 4, half-maximal inhibitory concentration: 4730 nM
Compound 4: middle estimate off by 1.2-fold (0.07 log units), on the low side; measured number inside the range.
By their numbers in this assay, from the lowest: compounds 2 and 4 (each within the scatter of the next); then compounds 1 and 3 (each within the scatter of the next).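

The step of a 1.1-fold higher number from compound 2 to compound 4 (0.05 log units; within the scatter) in this assay means that compound 2 and compound 4 cannot be told apart. The earlier compounds shown here only varied small groups on the aromatic ring, whereas here the group on this aromatic carbon, para to a large group, grows from a single chlorine atom to a whole phenyl ring of six heavy atoms and the number stays within the scatter. Nothing available explains why this exchange leaves the number unresolved, so the result describes only what was read in this cell assay.

The compounds shown leave open whether a group that carries an amine or a carboxylic acid on this same carbon would also stay within the scatter. They also do not tell whether a phenyl on another carbon of this ring would match compound 4.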